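Trifluoromethyl Enters the Aryl Ring of Compound 3

A few compounds are considered here, and "the series" means these few. Any claim that something is new, unique, unknown or untested is made for them only; others in the source may bear on it.

Measured compounds:
Compound 1, `COc1cc2c(Oc3ccc(NC(=O)c4nnn(-c5ccccc5C(F)(F)F)c4C)cc3F)ccnc2cc1OCCCN1CCCC1`, 200 nM
Compound 2, `COc1cc2c(Oc3ccc(NC(=O)c4nnn(-c5ccccc5C)c4C)cc3F)ccnc2cc1OCCCN1CCCCC1`, 450 nM
Compound 3, `COc1cc2c(Oc3ccc(NC(=O)c4nnn(-c5ccccc5)c4C)cc3F)ccnc2cc1OCCCN1CCCCC1`, 120 nM

These three share one core and differ in the group on the aryl ring attached to the triazole and in the cyclic amine at the end of the side chain. In a functional assay on HT-29 cells (Homo sapiens) for cytotoxicity, read by MTT assay, with a stated time of 72 h (on this read-out lower numbers stand for stronger inhibition and higher numbers for weaker inhibition), compound 3 gives 120 nM, the lowest of the three numbers; compound 1 sits within the scatter of it, while compound 2 lies beyond the scatter.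

Compound 4, `COc1cc2c(Oc3ccc(NC(=O)c4nnn(-c5ccccc5C(F)(F)F)c4C)cc3F)ccnc2cc1OCCCN1CCCCC1`, keeps everything of compound 3 except one change: trifluoromethyl in place of hydrogen on an aromatic carbon. For the measured compounds named here, the one step that bears on this is a 3.8-fold lower number from compound 2 to compound 3 (0.57 log units; beyond the scatter), where taking a methyl off the same position lowered the number. Putting a larger group back on could therefore be expected to raise it again. Against that, compound 1, which carries the same trifluoromethyl but a different amine, gives 200 nM, close to compound 3. A modest rise, or none beyond the scatter, is expected, so the estimate is a 2.1-fold higher number from compound 3 to compound 4 (0.32 log units; beyond the scatter), placing compound 4 at about 250 nM, between 100 nM and 600 nM.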

Compound 4, half-maximal inhibitory concentration: 200 nM
The estimate for compound 4 lay 1.3-fold (0.10 log units) above the measured number, and the stated range covers the measured number.
By their numbers in this assay, from the lowest: compounds 3, 1 and 4 (each within the scatter of the next); then compound 2.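

In this assay, trifluoromethyl in place of hydrogen on this aromatic carbon, ortho to a large group, gives a 1.7-fold higher number from compound 3 to compound 4 (0.22 log units; within the scatter), so these two compounds cannot be told apart and this position accepts trifluoromethyl. The comparison with methyl at the same carbon gives a 2.3-fold lower number from compound 2 to compound 4 (0.35 log units; beyond the scatter); among the three groups seen here, hydrogen, methyl and trifluoromethyl, only methyl separates from the others, so simply having a group on this carbon does not go with a higher number. With trifluoromethyl held in place, piperidin-1-yl in place of pyrrolidin-1-yl at the end of the side chain gives no change at the digits printed from compound 1 to compound 4 (within the scatter), so the two cyclic amines cannot be told apart in this setting.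

Nothing measured in these compounds explains why methyl parts from trifluoromethyl at this carbon.

From the compounds shown here alone, it also remains open whether a chlorine atom or a methoxy group on the same carbon would read like methyl or like trifluoromethyl, and whether a morpholin-4-yl group at the end of the side chain would match piperidin-1-yl and pyrrolidin-1-yl.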